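A Ring Swap on a Growth Inhibitor

This account rests on a few compounds, and the source may have more. Where it says the series, first, only, none or still open, it means among the compounds named here.

Within the data shown here, in a functional assay on KB cells (Homo sapiens) for inhibition, read by sulforhodamine B assay (a lower number here means a stronger inhibitor of growth, a higher number a weaker inhibitor of growth), compound 2 `COc1ccc(-c2ccc(-c3ccc(-c4nc5c(O)cccc5[nH]4)cc3)cc2)cc1` gives 4900 nM as the lower of the two numbers measured so far. The change 3-chlorophenyl in place of 4-methoxyphenyl on an aromatic carbon leads to compound 3 `Oc1cccc2[nH]c(-c3ccc(-c4ccc(-c5cccc(Cl)c5)cc4)cc3)nc12` and puts 3-chlorophenyl in place of 4-methoxyphenyl on an aromatic carbon. Among the measured compounds shown here, compound 1 `Clc1cccc(-c2ccc(-c3ccc(-c4nc5ccccc5[nH]4)cc3)cc2)c1` also carries 3-chlorophenyl and gives 32300 nM as a clearly higher number, but its core differs, so no measured pair isolates this swap. The expected step of a 2.2-fold higher number from compound 2 to compound 3 (0.35 log units; beyond the scatter) is upward, towards weaker growth inhibition, and moderate in size. Compound 3 is estimated at 11000 nM with a likely range of 3000 nM to 32000 nM in this assay when measured.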

Compound 3, concentration for 50% growth inhibition: 2280 nM
Compound 3: middle estimate off by 4.8-fold (0.68 log units), on the high side; the whole stated range lies above it.
By their numbers in this assay, from the lowest: compound 3; then compound 2; then compound 1.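

In this assay, replacing 4-methoxyphenyl with 3-chlorophenyl gives a 2.1-fold lower number from compound 2 to compound 3 (0.33 log units; beyond the scatter) and so shows that this aromatic carbon tolerates the swap, with growth inhibition improving modestly. Among these compounds, compound 3 also forms the first measured pair for hydroxy in place of hydrogen on the core, and this large change gives a 14-fold lower number from compound 1 to compound 3 (1.15 log units; beyond the scatter) as its step. No measurement at hand explains either step.

Still open, going by these compounds, is whether an amine or a carboxylic acid in place of the chlorine would strengthen growth inhibition further. Also open, on these data alone, is whether the hydroxy step would be as large with 4-methoxyphenyl in place of 3-chlorophenyl.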